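Dechlorination of a sulfonylated quinolone core

A few compounds are considered here, and "the series" means these few. Any claim that something is new, unique, unknown or untested is made for them only; others in the source may bear on it.

Measured in a functional assay on SUP-B15 cells (Homo sapiens) for antiproliferative activity, with a stated time of 72 h; on this read-out lower numbers stand for an effect already at smaller amounts and higher numbers for an effect only at larger amounts of compound:
compound 1 `COc1ccc(-c2c(Cl)c(=O)c3c(OC)cc(OC)cc3n2S(=O)(=O)c2ccc(OC)cc2)cc1` gives 17900 nM.
compound 2 `COc1ccc(-c2cc(=O)c3c(OC)cc(OC)cc3n2S(=O)(=O)c2ccc(Cl)cc2)cc1` gives > 34400 nM, which is a limit of the assay and not a number.
compound 3 `COc1ccc(-c2cc(=O)c3c(OC)cc(OC)cc3n2S(=O)(=O)c2ccc(Br)cc2)cc1` gives 63800 nM.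

Compound 1 stands lowest of the two numbers in this assay; compound 3 gives a higher number, and that gap lies beyond the scatter. The value of compound 2 is a limit only. Going by the values given here, the single step among the measured compounds, a step that the limit leaves unreadable from compound 2 to compound 3, cannot be sized because of the limit of > 34400 nM in this assay, at which 1 of the 3 values shown sits.

Compound 4 `COc1ccc(-c2cc(=O)c3c(OC)cc(OC)cc3n2S(=O)(=O)c2ccc(OC)cc2)cc1` differs from compound 1 in one place: hydrogen in place of chloro on an aromatic carbon. Among the compounds with values here, no measured step touches this position or this change, and the one measured step concerns a different ring and is unreadable. So there is nothing to set a direction for the step from compound 1 to compound 4; the expectation is a change within the scatter, with wide uncertainty and a real chance that only a limit is returned. Compound 4 is therefore expected at 25000 nM, within 8000 nM to 80000 nM, which means an estimated step of a 1.4-fold higher number from compound 1 to compound 4 (0.15 log units; within the scatter).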

Compound 4, half-maximal effective concentration: > 82700 nM
Compound 4 gave a limit, no number; the forecaster's own chance of this, stated with the estimate: 30%; middle value at least 3.3-fold (0.51 log units) away from the limit.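

Going by these compounds alone, until now no measured pair touched this position, and the new pair shows that in this assay the chloro group ortho to a 4-methoxyphenyl group cannot be exchanged for hydrogen without a readable loss: the change gives an at least 4.6-fold higher number from compound 1 to compound 4 (0.66 log units; beyond the scatter). The value of compound 4 is a limit and not a number: the limit of > 82700 nM in this assay, at which 1 of the 4 values shown sits.
Methoxy in place of bromo on the other ring gives an at least 1.2-fold higher number from compound 3 to compound 4 (0.11 log units; that floor lies within the scatter), while the step from compound 2 to compound 4 cannot be read.

The compounds shown carry only chloro or hydrogen at this position, so it remains open how a bromo, a methyl or an amine there would compare with chloro. Going by these compounds, it also remains open whether the effect of chloro holds when the (4-methoxyphenyl)sulfonyl group is exchanged for the bromo-bearing group of compound 3.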